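Swapping the Ester Group in a Kinase Inhibitor Series

The source may report more compounds than this note shows. Statements on the series, on what has been measured and on what is new or still open speak of the compounds shown alone.

Measured compounds:
compound 1 `NCc1ccc(C(=O)Nc2ccncc2F)cc1-c1cccc(C(=O)Oc2ccccc2)c1` gives 6.2 nM
compound 2 `NCc1ccc(C(=O)Nc2ccncc2)cc1-c1cccc(C(=O)OCC2CCCCC2)c1` gives 48 nM
compound 3 `NCc1ccc(C(=O)Nc2ccncc2)cc1-c1cccc(C(=O)OCc2ccccc2)c1` gives 45 nM

Of the compounds shown here, three sharing one core have been tested in an assay on isolated protein for inhibition of Rho-associated protein kinase 2 (Homo sapiens), read by radiometric assay; on this read-out higher numbers stand for weaker inhibition and lower numbers for stronger inhibition. Compound 1 has the lowest number of the three, and its gap to compound 3 and to compound 2 lies beyond the scatter of this assay. Compound 4 `NCc1ccc(C(=O)Nc2ccncc2F)cc1-c1cccc(C(=O)OCC2CCCCO2)c1` has not yet been measured. It differs from compound 1 in one place: (oxan-2-yl)methyl in place of phenyl on an oxygen next to a carbonyl group.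

Going by the values given here, only one measured step bears on this change. The step of a 1.1-fold lower number from compound 2 to compound 3 (0.03 log units; within the scatter) shows that exchanging a saturated ring for an aromatic one on the chain carbon of an ester changed nothing beyond the scatter. Compound 4 also changes the ester, but by inserting a chain carbon and a ring oxygen; compound 1 and compound 3 differ in two places at once, so their gap cannot be assigned to the ester alone. A modest weakening is therefore expected, a 2.4-fold higher number from compound 1 to compound 4 (0.38 log units; beyond the scatter). Compound 4 is estimated at 15 nM, within 5 nM to 50 nM.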

Compound 4, half-maximal inhibitory concentration: 12 nM
Beside the measured number, compound 4's estimate is 1.3-fold (0.10 log units) above it, and the stated range covers the measured number.
By their numbers in this assay, from the lowest: compounds 1 and 4 (each within the scatter of the next); then compounds 3 and 2 (each within the scatter of the next).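

In this assay, (oxan-2-yl)methyl in place of phenyl on an oxygen next to a carbonyl group gives a 1.9-fold higher number from compound 1 to compound 4 (0.29 log units; within the scatter) and so makes no change that can be told from the scatter. The earlier step exchanged one ring for another on the same chain carbon, whereas this one shows that the ring type and the way it is attached can change together on the shared core of compound 1 with the same outcome. Nothing available here explains this result.

As far as these compounds go, compound 2 and compound 3 carry a different core from compound 1 and compound 4, so it remains open whether each ester group would read the same on both cores. From the compounds shown here alone, it is also open how a carboxylic acid or an amide at this position, or a longer chain carrying the ring, would compare with compound 1.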